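Swapping dimethylamino for 4-methylpiperazin-1-yl in compound 2

The source may report more compounds than this note shows. Statements on the series, on what has been measured and on what is new or still open speak of the compounds shown alone.

Measured compounds and their values:
compound 1 `C=C1/C=C/C(=O)/C(CO)=C\C[C@](C)(CCC=C(C)C)/C=C/[C@H]1OC(=O)C=C(C)C`: 2750 nM
compound 2 `CC(C)=CCC[C@](C)(/C=C/[C@@H](OC(=O)C=C(C)C)[C@](C)(O)/C=C/C(=O)/C=C/N(C)C)CC=O`: 12200 nM

Both numbers come from a functional assay on MCF7 cells (Homo sapiens) for antiproliferative activity, read by MTT assay, with a stated time of 48 h; a lower number here means a stronger inhibitor, a higher number a weaker inhibitor. Compound 2 (12200 nM) has the higher of the two numbers. Compound 1 (2750 nM) lies lower by a gap beyond the usual scatter of repeated measurements, so compound 2 is the weaker inhibitor of this pair.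

The next compound is compound 3 `CC(C)=CCC[C@](C)(/C=C/[C@@H](OC(=O)C=C(C)C)[C@](C)(O)/C=C/C(=O)/C=C/N1CCN(C)CC1)CC=O`, which is not yet measured. It has 4-methylpiperazin-1-yl in place of dimethylamino on a double-bonded chain carbon bound to a double-bonded chain carbon. The rest of compound 2 stays the same. Going by the values given here, no two measured compounds differ in just one place, so the data show no measured step for this kind of change. The expectation therefore rests on compound 2 (12200 nM), the closest measured structure. In this assay no step beyond the scatter is expected, and no direction can be called with confidence. The expected step of a 1.2-fold lower number from compound 2 to compound 3 (0.09 log units; within the scatter) is small. For compound 3 the estimated value is 10000 nM (expected range 4500 nM to 22000 nM).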

Compound 3, half-maximal inhibitory concentration: 8840 nM
For compound 3 the middle estimate is 1.1-fold (0.05 log units) above the measured one, within the range that was stated.
By their numbers in this assay, from the lowest: compound 1; then compounds 3 and 2 (each within the scatter of the next).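

Going by these compounds alone, this is the first step that can be read at a single place, and in this assay it comes out as a 1.4-fold lower number from compound 2 to compound 3 (0.14 log units; within the scatter). The position, on a double-bonded chain carbon bound to a double-bonded chain carbon, therefore accepts 4-methylpiperazin-1-yl, with its six-membered non-aromatic ring and greater number of heavy atoms, in place of dimethylamino without a change that stands out from the usual scatter of repeated measurements. No supporting measurement accounts for the two groups reading alike, so this remains an observation without an explanation.

Both groups attach to the chain through a nitrogen atom, which leaves open how this position would read with a group lacking that nitrogen, such as a carboxylic acid or a plain butyl chain, or with another nitrogen ring, such as morpholin-4-yl. The compounds shown also leave open whether the same swap would read alike on the core of compound 1, which carries neither of these two groups.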